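Cytotoxicity notes: hydroxymethyl analogue of compound 3

The compounds below may be only part of what the source reports. "The series", "measured", "known", "first", "only" and "open" are said of these compounds alone.

Measured so far:
compound 1 `Clc1cccc(Cl)c1Cc1nnc(Nc2ccc(COCc3cccnc3)cc2)o1` gives 81000 nM
compound 2 `Fc1cccc(F)c1Cc1cnc(Nc2ccc(Oc3cccnc3)c(Br)c2)o1` gives 7500 nM
compound 3 `Fc1cccc(F)c1Cc1cnc(Nc2ccc(COc3ccncc3)cc2)o1` gives > 100000 nM

In an ADME assay on MT2 cells (Homo sapiens) for cytotoxicity, read by MTT assay (a lower number here means that less compound is tolerated, a higher number that more compound is tolerated), compound 1 gives 81000 nM and compound 2 gives 7500 nM. For compound 3 the read-out is a limit, not a number: compound 3 gives > 100000 nM, which is the limit of > 100000 nM in this assay, at which 1 of the 3 values shown sits. Among the measured compounds shown here, no pair of measured compounds differs in one place, so no measured step is available; the values of compound 1 and compound 2 stand on their own.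

Compound 4 `OCc1ccc(Nc2ncc(Cc3c(F)cccc3F)o2)cc1` differs from compound 3 by hydrogen in place of pyridin-4-yl on an oxygen on a saturated carbon. Cut one bond further out, the change reads (pyridin-4-yl)oxy to hydroxy, or ((pyridin-4-yl)oxy)methyl to hydroxymethyl.

For the measured compounds named here, with compound 3 at a limit and no measured step to lean on, the expectation for compound 4 in this assay is a number no higher from compound 3 to compound 4 (the limit leaves the size open), that is, no shift beyond the usual scatter. Compound 4 is estimated at 100000 nM, within 40000 nM to 300000 nM, and is expected most likely to be reported again as a limit rather than a number.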

Compound 4, half-maximal cytotoxic concentration: > 100000 nM
Compound 4: only a limit was reported; the forecaster's own chance of this, stated with the estimate: 65%; the middle value lies on the limit itself.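

In this assay compound 3 and compound 4 both stand at a limit, so no step between them can be read: the limit of > 100000 nM in this assay, at which 2 of the 4 values shown sit.

The compounds shown leave open whether hydrogen in place of pyridin-4-yl on an oxygen on a saturated carbon shifts the read-out in this assay at all.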